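Changing an Amide Substituent in a Cytotoxicity Series

This account rests on a few compounds, and the source may have more. Where it says the series, first, only, none or still open, it means among the compounds named here.

Measured so far in an ADME assay on MT4 cells (Homo sapiens) for cytotoxicity, read by MTT assay; on this read-out lower numbers stand for higher toxicity in this test and higher numbers for lower toxicity in this test
- Compound 1 `O=C(NCc1ccncc1)c1[nH]c2ccc(Cl)cc2c1S(=O)(=O)c1c(Cl)cccc1Cl` gives > 50200 nM as a limit of the assay and not a number
- Compound 2 `Cc1cc(C)cc(S(=O)(=O)c2c(C(=O)NC(C)c3cccnc3)[nH]c3ccc(Cl)cc23)c1` gives 54600 nM as a number

For the measured compounds named here, compound 2, at 54600 nM, holds the only true number in the set, so there is no second number against which to rank it. Compound 1 offers only its limit.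

Compound 3 `Cc1cc(C)cc(S(=O)(=O)c2c(C(=O)NCc3cccs3)[nH]c3ccc(Cl)cc23)c1` has not yet been measured. It keeps the rest of compound 2 and differs in one place, where the change is (thiophen-2-yl)methyl in place of 1-(pyridin-3-yl)ethyl on an amide-type nitrogen on an amide-type nitrogen. Going by the values given here, no step between measured compounds is available, so the series gives no direct guide to the size of this one. With compound 2 at 54600 nM as the sole numerical anchor, a modest move toward higher toxicity in this assay is expected, and it may not exceed the usual scatter. The estimated change is a 1.6-fold lower number from compound 2 to compound 3 (0.19 log units; within the scatter) in this assay on this basis. For compound 3 the expected value is 35000 nM within an estimated range of 10000 nM to 120000 nM in this measurement.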

Compound 3, half-maximal cytotoxic concentration: 54500 nM
For compound 3 the middle estimate is 1.6-fold (0.19 log units) below the measured one; measured number inside the range.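

The swap gives the series its first measured step: in this assay, the change is a 1.0-fold lower number from compound 2 to compound 3 (0.00 log units; within the scatter). On an amide-type nitrogen, then, a five-membered aromatic ring carrying sulfur can stand in for a six-membered aromatic ring carrying nitrogen, and the smaller (thiophen-2-yl)methyl group can replace 1-(pyridin-3-yl)ethyl, without any difference that this read-out can separate from scatter. This flat step may say little about the substituent itself, because the numbers of this pair lie close to the point where the read-out of compound 1 is only a limit and not a number: the limit of > 50200 nM in this assay, at which 1 of the 3 values shown sits.

The compounds shown leave open whether a quite different group on this nitrogen, such as one carrying a carboxylic acid or a primary amine, or a longer chain between the nitrogen and the ring, would shift the value in this assay beyond the scatter. For the compounds shown here, they also leave open whether the same exchange would read as flat on a core with another group on the sulfonyl, since only one such pair is available.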